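Four Aryl Variants on a Shared Core in Lung Cancer Cells

A few compounds are considered here, and "the series" means these few. Any claim that something is new, unique, unknown or untested is made for them only; others in the source may bear on it.

Compound 1, `O=C1COc2ccc(-c3[nH]c(-c4c[nH]c5ncccc45)nc3-c3ccccc3)cc2N1`: 100%
Compound 2, `O=C1COc2ccc(-c3[nH]c(-c4ccc(C(F)(F)F)cc4)nc3-c3ccccc3)cc2N1`: 103%
Compound 3, `O=C1COc2ccc(-c3[nH]c(-c4ccc(F)cc4)nc3-c3ccccc3)cc2N1`: 97.1%

All three compounds were measured in a functional assay on A549 cells (Homo sapiens) for cytotoxicity, read by colorimetric assay and MTT assay, with a stated time of 3 days, tested at 1 uM; on this read-out lower numbers stand for a stronger effect and higher numbers for a weaker effect at the one concentration tested. Compound 3 has the lowest of the three numbers, yet its separation from the others, a number 2.9 percentage points lower from compound 1 to compound 3 (within the scatter) and a number 5.9 percentage points lower from compound 2 to compound 3 (within the scatter), lies within the scatter, so no order among the three can be read from these values; the three compounds are indistinguishable on this read-out.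

Compound 4, `O=C1COc2ccc(-c3[nH]c(-c4ccc(Cl)cc4Cl)nc3-c3ccccc3)cc2N1`, differs from compound 3 in a single place: 2,4-dichlorophenyl in place of 4-fluorophenyl on an aromatic carbon. The change sits on the same aromatic carbon that was varied among the measured compounds, so all three measured steps bear on it. Each of them, a number 3 percentage points higher from compound 1 to compound 2 (within the scatter), a number 2.9 percentage points lower from compound 1 to compound 3 (within the scatter) and a number 5.9 percentage points lower from compound 2 to compound 3 (within the scatter), is within the scatter, and the closest in kind, a swap of one halogen-bearing phenyl group for another, is the step from compound 2 to compound 3. Nothing in these steps points to a change beyond the scatter; the expected step is a number 2.9 percentage points higher from compound 3 to compound 4 (within the scatter). Compound 4 is therefore estimated at 100% in this assay , with a range from 88% to 110%.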

Compound 4, a percentage reported as activity, at one concentration (the size of the read-out at that concentration, not a potency): 97.4%
For compound 4 the middle estimate is 2.6 percentage points above the measured one; the measured number falls inside the stated range.
By their numbers in this assay, from the lowest: compounds 3, 4, 1 and 2 (each within the scatter of the next).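

In this assay, placing 2,4-dichlorophenyl on this aromatic carbon, between two ring nitrogen atoms, gives a number 0.3 percentage points higher from compound 3 to compound 4 (within the scatter), and comparing the same group with the other two gives a number 5.6 percentage points lower from compound 2 to compound 4 (within the scatter) and a number 2.6 percentage points lower from compound 1 to compound 4 (within the scatter). Chlorine, absent from the earlier compounds, thus enters at this position without any step leaving the scatter, so the four groups tested on this carbon cannot be told apart at the one concentration used. No measurement offered here accounts for this outcome.

All four compounds carry an aromatic ring on this carbon, so the compounds shown leave open whether a different kind of group there, such as an amine, a carboxylic acid or a longer alkyl chain, would move the read-out beyond the scatter. They also leave open what would follow from replacing the phenyl group two ring bonds away with a pyridine ring, or from changing the shared core itself, and how any of these compounds would behave at another concentration.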